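The source may report more compounds than this note shows. Statements on the series, on what has been measured and on what is new or still open speak of the compounds shown alone.

Measured so far in a functional assay on HEK293 cells for agonist activity at Free fatty acid receptor 1 (Homo sapiens), read by fluorescence and calcium flux; on this read-out lower numbers stand for an effect already at smaller amounts and higher numbers for an effect only at larger amounts of compound:
- Compound 1 `CC#CC(CC(=O)O)c1ccc(OCc2ccc(C(=O)N3CCN(C)CC3)s2)cc1`: compound 1 gives > 5000 nM, which is a limit of the assay and not a number.
- Compound 2 `CC#CC(CC(=O)O)c1ccc(OCc2ccc(C(=O)N3CCN(c4ccc(C(C)(C)C)cc4)CC3)s2)cc1`: compound 2 gives 417 nM.
- Compound 3 `CC#CC(CC(=O)O)c1ccc(OCc2ccc(C(=O)N3CCN(c4ccc(OC)cc4)CC3)s2)cc1`: compound 3 gives 289 nM.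

Compound 3 holds the lowest of the two numbers; its nearest neighbour is compound 2, and the gap between them, a 1.4-fold lower number from compound 2 to compound 3 (0.16 log units; within the scatter), lies within the scatter. The third value is the limit (the limit of > 5000 nM in this assay, at which 1 of the 3 values shown sits), which belongs to compound 1 alone.

Compound 4 `CC#CC(CC(=O)O)c1ccc(OCc2ccc(C(=O)N3CCN(c4ccccc4[N+](=O)[O-])CC3)s2)cc1` is not yet measured. It differs from compound 3 in one place: 2-nitrophenyl in place of 4-methoxyphenyl on an amine nitrogen in a ring.

Going by the values given here, two measured steps bear on this change. Replacing methyl by an aryl group on the ring nitrogen gave an at least 11-fold lower number from compound 1 to compound 2 (1.07 log units; beyond the scatter) and an at least 17-fold lower number from compound 1 to compound 3 (1.23 log units; beyond the scatter), both large. Exchanging the substituent on that aryl ring gave a 1.4-fold lower number from compound 2 to compound 3 (0.16 log units; within the scatter), within the scatter. Compound 4 keeps an aryl group on the ring nitrogen, so the large gain seen in compound 2 and compound 3 is expected to hold, while the change of substituent pattern is expected to move the number no further than the scatter. The step from compound 3 to compound 4 in this assay is therefore expected to be a 1.4-fold higher number from compound 3 to compound 4 (0.14 log units; within the scatter). For compound 4 the estimate in this assay is 400 nM, with a range from 120 nM to 1300 nM.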

Compound 4, half-maximal effective concentration: 94 nM
Compound 4: middle estimate off by 4.3-fold (0.63 log units), on the high side; measured number outside the range, below it.
By their numbers in this assay, from the lowest: compound 4; then compounds 3 and 2 (each within the scatter of the next). At a limit, above all of these: compound 1.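

In this assay, going by these compounds alone, the substituent on the aryl ring at the ring nitrogen now matters: 2-nitrophenyl gives a 3.1-fold lower number from compound 3 to compound 4 (0.49 log units; beyond the scatter) and a 4.4-fold lower number from compound 2 to compound 4 (0.65 log units; beyond the scatter), whereas the one earlier exchange on that aryl ring, methoxy for tert-butyl, stayed within the scatter. Compound 4 therefore stands alone at the low end of the series, while compound 2 and compound 3 remain unseparated. Set against the methyl group on the ring nitrogen, 2-nitrophenyl gives an at least 53-fold lower number from compound 1 to compound 4 (1.72 log units; beyond the scatter), which is only a bound, the starting value being a limit: the limit of > 5000 nM in this assay, at which 1 of the 4 values shown sits.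

Compound 4 changes both the substituent and its place on the aryl ring, so the compounds shown do not tell whether the lower number goes with the nitro group or with where it sits; 4-nitrophenyl and 2-methoxyphenyl on the same ring nitrogen would separate the two. Also open, going by these compounds, is whether the lower number is particular to the nitro group or is shared by other groups in the same place, such as a nitrile, a trifluoromethyl or an amine.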